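Inverting Both Stereocentres of the Saturated Azido Phosphate

A few compounds are considered here, and "the series" means these few. Any claim that something is new, unique, unknown or untested is made for them only; others in the source may bear on it.

Measured in an assay on isolated protein for inhibition of sphingosine-1-phosphate lyase 1 (Homo sapiens), using Lineweaver-Burk analysis; a higher number here means a weaker inhibitor, a lower number a stronger inhibitor:
compound 1 `CCCCCCCCCCCCC/C=C/[C@H](O)[C@H](COP(=O)(O)O)N=[N+]=[N-]` gives 20400 nM
compound 2 `CCCCCCCCCCCCCCC[C@H](O)[C@@H](COP(=O)(O)O)N=[N+]=[N-]` gives 6300 nM
compound 3 `CCCCCCCCCCCCC/C=C/[C@@H](O)[C@@H](COP(=O)(O)O)N=[N+]=[N-]` gives 17500 nM

Compound 2 stands at the lowest of the three numbers; compound 3 and compound 1 both sit above it, each beyond the scatter. Compound 4 `CCCCCCCCCCCCCCC[C@@H](O)[C@H](COP(=O)(O)O)N=[N+]=[N-]` is its counterpart: the two compounds have the same atoms and bonds; at least one stereo element is drawn with a configuration in one of them and without one in the other: 2 of 3 stereo elements differ; a stereocentre at a saturated chain carbon is drawn S in compound 2 and R in compound 4; a stereocentre at a saturated chain carbon is drawn R in compound 2 and S in compound 4. Among the measured compounds shown here, one measured step is of the same kind, the pairing of compound 1 with compound 3, and there a 1.2-fold lower number from compound 1 to compound 3 (0.07 log units; within the scatter); the only evidence on that pair is the fact that one of compounds 1 and 3 is drawn with a defined configuration and the other without, at the place where they differ. Since swapping both chain stereocentres left the number unchanged within the scatter once, the same is expected here in this assay: a 1.2-fold higher number from compound 2 to compound 4 (0.08 log units; within the scatter), no step beyond the scatter. Compound 4 is therefore estimated at 7500 nM, within 3000 nM to 18000 nM.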

Compound 4, inhibition constant: 19000 nM
Compound 4: the middle estimate sits 2.5-fold (0.40 log units) below what was measured; the whole stated range lies below it.
By their numbers in this assay, from the lowest: compound 2; then compounds 3, 4 and 1 (each within the scatter of the next).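

In this assay, inverting both chain stereocentres does change the number in the saturated pair: a 3.0-fold higher number from compound 2 to compound 4 (0.48 log units; beyond the scatter). The same kind of swap in the pair with the chain double bond stayed within the scatter, a 1.2-fold lower number from compound 1 to compound 3 (0.07 log units; within the scatter), so the earlier step does not carry over to this chain. The only evidence on the new pair gives no cause: the fact that one of compounds 2 and 4 is drawn with a defined configuration and the other without, at the place where they differ

Since both stereocentres change together, the compounds shown leave open whether one alone accounts for the step. They also leave open how an amine in place of the azide would fare.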